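The compounds below may be only part of what the source reports. "The series", "measured", "known", "first", "only" and "open" are said of these compounds alone.

Compound 1, `CCN(CC)Cc1ccc2nc(NC(=O)N/N=C/c3cn(Cc4ccccc4Cl)c4ccccc34)sc2c1`, gives 980 nM in a functional assay on NCI-H460 cells (Homo sapiens) for cytotoxicity, read by MTT assay, with a stated time of 72 h; a lower number here means a stronger inhibitor, a higher number a weaker inhibitor.
Compound 2, `CC1CCN(Cc2ccc3nc(NC(=O)N/N=C/c4cn(Cc5cccc(Cl)c5)c5ccccc45)sc3c2)CC1`, gives 280 nM in this assay.
Compound 3, `CCN(CC)Cc1ccc2nc(NC(=O)N/N=C/c3c[nH]c4ccccc34)sc2c1`, gives 3140 nM in this assay.

Among these three numbers compound 3 stands highest, which in this assay means it is the weakest inhibitor of the set: compound 1 sits nearest to it, and compound 2 furthest away, each with a lower number beyond the usual scatter.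

Compound 4, `CCN(CC)Cc1ccc2nc(NC(=O)N/N=C/c3cn(Cc4cccc(Cl)c4)c4ccccc34)sc2c1`, is not yet measured. It differs from compound 3 in one place: 3-chlorobenzyl in place of hydrogen on an aromatic nitrogen.

Within the data shown here, one measured step bears directly on this change, though it runs the other way: a 3.2-fold higher number from compound 1 to compound 3 (0.51 log units; beyond the scatter). Removing a chlorobenzyl from that aromatic nitrogen thus raised the number by a modest amount, so putting a chlorobenzyl back in its place should be expected to lower it by a similar amount. Compound 2 also carries a 3-chlorobenzyl on the same nitrogen and shows a low number, but it differs from compound 3 in a second place as well, so its value only hints at the direction and is not a clean comparison.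

On this basis compound 4 is expected to be a stronger inhibitor than compound 3, by a step of roughly a 3.9-fold lower number from compound 3 to compound 4 (0.59 log units; beyond the scatter). The estimate for compound 4 is 800 nM, within a range of 300 nM to 2000 nM.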

Compound 4, half-maximal inhibitory concentration: 220 nM
For compound 4 the middle estimate is 3.6-fold (0.56 log units) above the measured one; measured number below the stated range.
By their numbers in this assay, from the lowest: compounds 4 and 2 (each within the scatter of the next); then compound 1; then compound 3.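

In this assay, placing a 3-chlorobenzyl on the aromatic nitrogen gives a 14-fold lower number from compound 3 to compound 4 (1.15 log units; beyond the scatter), so this position can respond strongly to what is attached there. The place of the chlorine on the benzyl ring also counts, as moving from the 2-chlorobenzyl to the 3-chlorobenzyl gives a 4.5-fold lower number from compound 1 to compound 4 (0.65 log units; beyond the scatter), a step beyond the scatter even though the two groups have the same atoms. By contrast, the change from 4-methylpiperidin-1-yl to diethylamino gives a 1.3-fold lower number from compound 2 to compound 4 (0.10 log units; within the scatter), which is within the scatter, so with a 3-chlorobenzyl on the nitrogen these two amine groups cannot be told apart in this assay.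

The compounds shown leave open how much of the gain needs the chlorine at all, since an unsubstituted benzyl or a 3-fluorobenzyl on the same nitrogen would be needed to separate the contribution of the ring from that of the halogen. No measurement available here explains why the 3-chlorobenzyl and the 2-chlorobenzyl give different numbers.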